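A few compounds are considered here, and "the series" means these few. Any claim that something is new, unique, unknown or untested is made for them only; others in the source may bear on it.

In a functional assay on MCF7 cells (Homo sapiens) for antiproliferative activity (a lower number here means a stronger inhibitor, a higher number a weaker inhibitor), compound 1 `CC(C)=CCc1cc(C(=O)Nc2cc3ccc(OCC4CCN(C)C4)c(C)c3oc2=O)ccc1O` gives 1550 nM, and compound 2 `CC(C)=CCc1cc(C(=O)Nc2cc3ccc(OCCCNCC(N)=O)c(C)c3oc2=O)ccc1O` gives 1460 nM. Among the compounds with values here, these two values lie within the scatter of each other, so compound 2 stands level with the only other measured compound. Compound 3 `CC(C)=CCc1cc(C(=O)Nc2cc3ccc(OCCCNc4ccccc4)c(C)c3oc2=O)ccc1O` differs from compound 2 by phenyl in place of carbamoylmethyl on an amine nitrogen. Within the data shown here, one measured step bears on this change, an exchange of groups on the same saturated chain, and it amounts to a 1.1-fold lower number from compound 1 to compound 2 (0.03 log units; within the scatter). Among the measured compounds shown here, no measured compound carries phenyl on that amine nitrogen, so this evidence is thin. Starting from compound 2 at 1460 nM, no step beyond the scatter is expected in this assay. The estimated change is a 1.1-fold lower number from compound 2 to compound 3 (0.05 log units; within the scatter). For compound 3 the expected value is 1300 nM, with an estimated range from 500 nM to 3500 nM.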

Compound 3, half-maximal inhibitory concentration: > 50000 nM
Compound 3 was reported as a limit; the forecaster's own chance of this, stated with the estimate: 5%; middle value at least 38-fold (1.58 log units) away from the limit.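

Compound 3 stands at a limit of the assay, not at a number: the limit of > 50000 nM in this assay, at which 1 of the 3 values shown sits. This shows that the amine nitrogen on this chain does not tolerate every group, since phenyl in place of carbamoylmethyl gives an at least 34-fold higher number from compound 2 to compound 3 (1.53 log units; beyond the scatter), and the change of the whole side chain gives an at least 32-fold higher number from compound 1 to compound 3 (1.50 log units; beyond the scatter). The earlier pair had suggested a side chain that could vary freely, but that picture holds only for compound 1 and compound 2.

The compounds shown cannot tell whether the aromatic ring on the nitrogen or the absence of carbamoylmethyl matters more, and a benzyl or a plain methyl on that amine nitrogen would help to separate the two. Going by these compounds, how far the true value of compound 3 lies past its limit also stays open.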